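Cyclohexylcarbamoyl in Place of Phenylsulfonyl on the Shared Core

The compounds below may be only part of what the source reports. "The series", "measured", "known", "first", "only" and "open" are said of these compounds alone.

Compound 1 `CCCCc1ccc(CNS(=O)(=O)c2ccccc2)c(=O)n1Cc1ccc(-c2ccccc2-c2nn[nH]n2)cc1`: 25.2%
Compound 2 `CCCCc1ccc(CNC(=O)OC(C)(C)C)c(=O)n1Cc1ccc(-c2ccccc2-c2nn[nH]n2)cc1`: 68.9%
Compound 3 `CCCCc1ccc(CNC(=O)N(C)C)c(=O)n1Cc1ccc(-c2ccccc2-c2nn[nH]n2)cc1`: 28%

The three measured compounds share one core and differ only in the group on the amine nitrogen. In a functional assay on the whole organism (artery) for inhibition, with Rattus norvegicus as the target, at a dose of 3 mg/kg by the intraduodenal route (a lower number here means less inhibition, a higher number more inhibition at the dose given (going by the name of the read-out)), compound 1 has the lowest of the three numbers; compound 3 sits within the scatter of it, while compound 2 stands well beyond it, a number 43.7 percentage points higher from compound 1 to compound 2 (beyond the scatter). The step of a number 2.8 percentage points higher from compound 1 to compound 3 (within the scatter) shows that a dimethylcarbamoyl group alone does not move the read-out, whereas a number 40.9 percentage points lower from compound 2 to compound 3 (beyond the scatter) shows how much the carbamate and the urea differ.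

Compound 4 `CCCCc1ccc(CNC(=O)NC2CCCCC2)c(=O)n1Cc1ccc(-c2ccccc2-c2nn[nH]n2)cc1` is not yet measured. Relative to compound 1 it carries cyclohexylcarbamoyl in place of phenylsulfonyl on an amine nitrogen. Both earlier steps from compound 1 bear on it: the urea of compound 3 brought no change, the carbamate of compound 2 a large gain. Because a number 2.8 percentage points higher from compound 1 to compound 3 (within the scatter) was flat and a number 43.7 percentage points higher from compound 1 to compound 2 (beyond the scatter) large, compound 4 is expected to show an upward step that lies between them, estimated as a number 16.8 percentage points higher from compound 1 to compound 4 (beyond the scatter). Compound 4 is therefore estimated at 42%, within a range from 18% to 70%.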

Compound 4, a percentage reported as inhibition, in the whole organism at one dose (the size of the read-out at that dose, not a potency): 0%
Estimate against measurement, compound 4: 42 percentage points above; the measured number lies below the stated range.
By their numbers in this assay, from the lowest: compound 4; then compounds 1 and 3 (each within the scatter of the next); then compound 2.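

In this assay, cyclohexylcarbamoyl on the amine nitrogen gives the lowest read-out of the four compounds, with a number 25.2 percentage points lower from compound 1 to compound 4 (beyond the scatter), a number 28 percentage points lower from compound 3 to compound 4 (beyond the scatter) and a number 68.9 percentage points lower from compound 2 to compound 4 (beyond the scatter). The two ureas, compound 3 and compound 4, therefore do not behave alike: the read-out at this position depends on the group on the carbonyl carbon, and not only on whether a urea or a carbamate is present. Nothing in the available data explains the drop.

The compounds shown leave open whether the low number goes with the cyclohexyl ring or with the hydrogen on the urea nitrogen, which a methylamino or phenylamino group on the carbonyl carbon could help to separate. They also leave open whether a methoxy group in place of tert-butoxy would keep the read-out of compound 2.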